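A few compounds are considered here, and "the series" means these few. Any claim that something is new, unique, unknown or untested is made for them only; others in the source may bear on it.

Compound 1 `CC(C(=O)N1CCN(c2ccccc2)CC1)N1C(=O)CCC1=O`: 0%
Compound 2 `CC(C(=O)N1CCN(c2ccccc2F)CC1)N1C(=O)CCC1=O`: 0%

Going by the values given here, in a functional assay on the whole organism (strain Swiss) with Mus musculus as the target, in the maximal electroshock model, with a stated time of 1 h, at a dose of 100 mg/kg by the intraperitoneal route (a higher number here means a stronger effect of the compound at the dose given, a lower number a weaker effect), compound 1 gives 0%, and compound 2 gives 0%, so compound 1 stands level with compound 2, its single neighbour in the data. Among the compounds with values here, the sole measured step, no change at the digits printed from compound 1 to compound 2 (within the scatter), is the only one that bears on the change to compound 3 `CC(C(=O)N1CCN(c2cccc(C(F)(F)F)c2)CC1)N1C(=O)CCC1=O`, namely (trifluoromethyl in place of hydrogen on an aromatic carbon). That step showed no change, and compound 1 itself shows no effect at the dose tested. From this the expected step in this assay is no change at the digits printed from compound 1 to compound 3 (within the scatter), none beyond the scatter. Compound 3 is therefore estimated at 0%, within a range from 0% to 20%.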

Compound 3, a percentage reported as activity, at one dose (the size of the read-out at that dose, not a potency): 50%
Compound 3: middle estimate off by 50 percentage points, on the low side; measured number outside the range, above it.
By their numbers in this assay, from the lowest: compounds 1 and 2 (each within the scatter of the next); then compound 3.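

In this assay, the aromatic ring of the shared core proves able to carry a change that counts: trifluoromethyl in place of hydrogen, meta to a large group, gives a number 50 percentage points higher from compound 1 to compound 3 (beyond the scatter). The fluoro change had shown nothing of the kind, with no change at the digits printed from compound 1 to compound 2 (within the scatter). Nothing measured here accounts for the gain. Still open, on these data alone, is whether chloro or methoxy at this place would give a similar read-out, and whether trifluoromethyl elsewhere on the ring would keep it.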